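Distal aryl variation on the shared core

A few compounds are considered here, and "the series" means these few. Any claim that something is new, unique, unknown or untested is made for them only; others in the source may bear on it.

In an assay on isolated protein for binding affinity to 5-hydroxytryptamine receptor 1B (Homo sapiens) (on this read-out lower numbers stand for stronger inhibition and higher numbers for weaker inhibition), compound 2 `COc1cc2c(cc1N1C[C@@H](C)N[C@@H](C)C1)N(C(=O)c1ccc(-c3ccc(C(C)=O)cc3C)cc1)CC2` gives 3.16 nM, the lowest of the three numbers. Compound 1 `COc1cc2c(cc1N1C[C@@H](C)N(C)[C@@H](C)C1)N(C(=O)Nc1cccc(C(F)(F)F)c1F)CC2` gives 3.98 nM in this assay, within the scatter of compound 2. Compound 3 `COc1cc2c(cc1N1C[C@@H](C)N[C@@H](C)C1)N(C(=O)c1ccc(-c3cc(C)ncc3C)cc1)CC2` gives 7.94 nM, and the step of a 2.5-fold higher number from compound 2 to compound 3 (0.40 log units; beyond the scatter) is the only one beyond the scatter; it came from exchanging the distal aryl group. Compound 4 `COc1cc2c(cc1N1C[C@@H](C)N[C@@H](C)C1)N(C(=O)c1ccc(-c3ccc(-c4ncccn4)cc3C)cc1)CC2` differs from compound 2 by pyrimidin-2-yl in place of acetyl on an aromatic carbon. Among the measured compounds shown here, only the step of a 2.5-fold higher number from compound 2 to compound 3 (0.40 log units; beyond the scatter) bears on this change, since it also altered the distal aryl group; a loss of similar or smaller size, or none beyond the scatter, is therefore expected for compound 4 in this assay. The estimate for compound 4 is 5 nM, range 2 nM to 15 nM, an expected step of a 1.6-fold higher number from compound 2 to compound 4 (0.20 log units; within the scatter).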

Compound 4, inhibition constant: 5.01 nM
For compound 4 the middle estimate is 1.0-fold (0.00 log units) below the measured one; the measured number falls inside the stated range.
By their numbers in this assay, from the lowest: compounds 2, 1, 4 and 3 (each within the scatter of the next, the first and the last beyond it).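

In this assay, the step of a 1.6-fold higher number from compound 2 to compound 4 (0.20 log units; within the scatter) shows that this position, meta to a methyl group, accepts a whole six-membered aromatic ring with two hetero atoms in place of acetyl, with no change beyond the scatter. The acetyl carbonyl is therefore not needed to keep the number within the scatter of compound 2. The step of a 2.5-fold higher number from compound 2 to compound 3 (0.40 log units; beyond the scatter) exchanged the entire distal aryl group, whereas this change alters only the group on it.

On these data alone, whether an amine or a carboxylic acid at this position would do the same remains open. No data at hand explain why acetyl and pyrimidin-2-yl read alike.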